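The compounds below may be only part of what the source reports. "The series", "measured", "known", "first", "only" and "open" are said of these compounds alone.

Measured so far:
compound 1 `CC(C)(C)OC(=O)n1cc(-c2ccc(NC(=O)c3ccco3)cc2)nc1N` in an assay on isolated protein for inhibition of sodium channel protein type 4 subunit alpha (Homo sapiens), read by electrophysiology, with a stated time of 4 min; on this read-out lower numbers stand for stronger inhibition and higher numbers for weaker inhibition: > 30000 nM
compound 2 `CC(C)(C)OC(=O)n1cc(-c2cccc(NC(=O)[C@H]3CCCN3)c2)nc1N` in this assay : > 30000 nM

Compound 1 stands on no number at all: in this assay compound 1 gives only a limit, > 30000 nM, which means the assay reports no inhibition up to its highest tested concentration. Compound 2 sits on the same footing, giving only the limit > 30000 nM in this assay. Thus the limit of > 30000 nM in this assay, at which 2 of the 2 values shown sit, holds for everything measured here, and no step between measured compounds can be sized.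

Compound 3 `CC(C)(C)OC(=O)n1cc(-c2ccc(NC(=O)[C@H]3CCCN3)cc2)nc1N` is not yet measured. It differs from compound 1 by pyrrolidin-2-yl in place of furan-2-yl on a carbonyl carbon. With both measured compounds at the limit, there is no basis for expecting a step in either direction beyond the scatter in this assay; the expected change from compound 1 to compound 3 is a number no higher from compound 1 to compound 3 (the limit leaves the size open). Compound 3 is therefore expected to give about 30000 nM in this assay, within a range from 8000 nM to 100000 nM.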

Compound 3, half-maximal inhibitory concentration: > 30000 nM
Compound 3: a limit, no number (the forecaster's own chance of this, stated with the estimate: 75%); the middle value lies on the limit itself.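

In this assay compound 3 gives > 30000 nM, which is a limit and not a number. Among the compounds shown here, compound 1 also gives only a limit, so no step between compound 1 and compound 3 can be read. The compounds shown leave open whether pyrrolidin-2-yl in place of furan-2-yl changes inhibition at all.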